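The source may hold more compounds than are shown below. What is called first, only, known or untested is meant among the compounds shown, and "the series" means these compounds.

Measured compounds in the series:
- compound 1 `COc1ccc(-c2nnc(SCC(=O)NNC(=O)c3ccccc3O)n2-c2ccccc2)cc1OC` — in an ADME assay on HCT-116 cells (Homo sapiens) for cytotoxicity (a lower number here means that less compound is tolerated, a higher number that more compound is tolerated), compound 1 returns only a limit, > 20000 nM.
- compound 2 `Cc1cc(C)nc(SCc2nnc(SCC(=O)NNC(=O)c3ccccc3O)n2-c2ccccc2)n1` — in this assay compound 2 returns only a limit, > 20000 nM.
- compound 3 `Cc1cc(C)nc(SCc2nnc(SCC(=O)NNC(=O)c3ccccc3O)n2C)n1` — not yet measured in this assay.

Compound 2 stands at the limit of this assay; both values shown sit there, (the limit of > 20000 nM in this assay, at which 2 of the 2 values shown sit), so no number is known for it. For the measured compounds named here, the one measured step, a step that the two limits leave unreadable from compound 1 to compound 2, is unreadable: with both ends at the limit, neither its size nor its direction can be taken from the data.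

The step to compound 3 is methyl in place of phenyl on an aromatic nitrogen. Going by the values given here, no measured step touches this position, so there is nothing to transfer to it; the only bearing is that the two measured compounds are tolerated up to the limit. It is expected that compound 3 also gives no readable number, and the estimated step that the limit leaves unreadable from compound 2 to compound 3 is set to nothing beyond the scatter. For compound 3 the estimate in this assay is 30000 nM, with a range from 12000 nM to 80000 nM, most likely reported as a limit again.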

Compound 3, half-maximal cytotoxic concentration: > 20000 nM
Compound 3: only a limit was reported; the forecaster's own chance of this, stated with the estimate: 80%; the middle value lies beyond the limit too.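

No new step can be read: compound 2 and compound 3 both return only a limit in this assay, leaving the change from phenyl to methyl without readable size or direction. The series stays at one limit: the limit of > 20000 nM in this assay, at which 3 of the 3 values shown sit.

The compounds shown leave open the actual half-maximal cytotoxic concentration of all three compounds.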